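From Chloro to Nitro in a Growth-Inhibition Series

The source may hold more compounds than are shown below. What is called first, only, known or untested is meant among the compounds shown, and "the series" means these compounds.

- compound 1 `Cc1ccc(/C=C(\C(=O)c2ccc([N+](=O)[O-])cc2)S(=O)(=O)Cc2ccc(Cl)cc2)s1` gives 25000 nM
- compound 2 `COc1ccccc1/C=C(\C(=O)c1ccc(Cl)cc1)S(=O)(=O)Cc1ccc(Cl)cc1` gives 25000 nM

Both numbers come from a functional assay on DU-145 cells (Homo sapiens) for inhibition, read by trypan blue exclusion, with a stated time of 96 h (on this read-out higher numbers stand for weaker inhibition of growth and lower numbers for stronger inhibition of growth), and compound 2 stands level with compound 1 at the digits shown, with nothing separating them beyond the usual scatter. These two compounds differ in more than one place, so their matching values say little about any single group.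

The next compound is compound 3 `COc1ccccc1/C=C(\C(=O)c1ccc([N+](=O)[O-])cc1)S(=O)(=O)Cc1ccc(Cl)cc1`, which keeps everything in compound 2 except one group: nitro in place of chloro on an aromatic carbon, para to a large group (nitro in place of chloro on an aromatic carbon). The same difference reads as 4-chlorophenyl to 4-nitrophenyl. Among the measured compounds shown here, no measured pair shows this swap alone. The nearest clue is compound 1, which carries the 4-nitrophenyl group alongside other differences and gives 25000 nM in this assay. The expectation is therefore no step beyond the scatter in this assay, with only a slight lean toward stronger inhibition. In estimated terms, that means a 1.4-fold lower number from compound 2 to compound 3 (0.14 log units; within the scatter). For compound 3 the estimated value is 18000 nM, with an expected range of 4000 nM to 50000 nM.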

Compound 3, concentration for 50% growth inhibition: 10000 nM
For compound 3 the middle estimate is 1.8-fold (0.26 log units) above the measured one; the measured number falls inside the stated range.
By their numbers in this assay, from the lowest: compound 3; then compounds 1 and 2 (each within the scatter of the next).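

In this assay, among the compounds shown here, the change from 4-chlorophenyl to 4-nitrophenyl, with everything else held fixed, gives a 2.5-fold lower number from compound 2 to compound 3 (0.40 log units; beyond the scatter) and so offers the first clean reading of this swap on an aromatic carbon para to a large group, a modest step toward stronger inhibition of growth. Compound 1 already carried the 4-nitrophenyl group, and with that group held fixed, 2-methoxyphenyl in place of 5-methylthiophen-2-yl gives a 2.5-fold lower number from compound 1 to compound 3 (0.40 log units; beyond the scatter) and shows that the 4-nitrophenyl group does not set the number alone, since the group on the double-bonded chain carbon moves it by a modest step too. Nothing measured here speaks to the reason for either step.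

The compounds shown leave open how other groups at this aromatic position, such as an amine or a nitrile, would compare with chloro and nitro. They also leave open whether the step from 4-chlorophenyl to 4-nitrophenyl would keep its size in a compound carrying the 5-methylthiophen-2-yl group, and whether a larger change in growth inhibition is reachable from either place.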